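The source may hold more compounds than are shown below. What is called first, only, known or untested is meant among the compounds shown, and "the series" means these compounds.

Compound 1 `NS(=O)(=O)c1ccc(S(=O)(=O)Nc2cccc(-c3nc(-c4ccc(NC(=O)c5cccnc5)cc4Cl)no3)c2)cc1` carries a sulfamoyl group on the benzenesulfonamide ring of the shared core. In a functional assay on MDA-MB-231 cells (Homo sapiens) for antiproliferative activity, read by MTT assay, with a stated time of 72 h (a lower number here means a stronger inhibitor, a higher number a weaker inhibitor), compound 1 gives only a limit, > 10000 nM, and no number. Among the measured compounds shown here, compound 2 `COc1cc(-c2noc(-c3cccc(NS(=O)(=O)c4ccc(NC(C)=O)cc4)c3)n2)ccc1NC(=O)c1cccnc1` is the only other compound measured. In this assay compound 2 likewise gives only a limit, > 10000 nM. Where compound 1 stands is therefore defined by the limit of > 10000 nM in this assay, at which 2 of the 2 values shown sit, so nothing separates it from compound 2, and no step between measured compounds can be read off.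

Compound 3 `O=C(Nc1ccc(S(=O)(=O)Nc2cccc(-c3nc(-c4ccc(NC(=O)c5cccnc5)cc4Cl)no3)c2)cc1)NC1CCCC1` has not yet been measured in this assay. It differs from compound 1 in one place: (cyclopentylcarbamoyl)amino in place of sulfamoyl on an aromatic carbon.

For the measured compounds named here, with both measured values sitting at the limit, there is no measured step to rest an expected direction on. The step from compound 1 to compound 3 in this assay is expected to be a step that the limit leaves unreadable from compound 1 to compound 3, that is, no change beyond the scatter. Compound 3 is accordingly estimated at 15000 nM, with a range from 3000 nM to 60000 nM, and most likely again only a limit.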

Compound 3, half-maximal inhibitory concentration: > 10000 nM
Compound 3 gave a limit, no number; the forecaster's own chance of this, stated with the estimate: 70%; the middle value lies beyond the limit too.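

No step from compound 1 to compound 3 can be read, because the result for compound 3 is again only a limit of the assay and not a number: the limit of > 10000 nM in this assay, at which 3 of the 3 values shown sit.

The compounds shown leave open how the sulfamoyl and (cyclopentylcarbamoyl)amino groups compare in this assay, and whether any change to the shared core gives a measurable value there.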